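This account rests on a few compounds, and the source may have more. Where it says the series, first, only, none or still open, it means among the compounds named here.

Compound 1 `COc1cccc(/C=C/C(=O)Nc2cc(C(=O)c3cc(OC)c(OC)c(OC)c3)ccc2OC)c1` and compound 2 `COc1ccc(C(=O)c2cc(OC)c(OC)c(OC)c2)cc1NC(=O)/C=C/c1cccc(OC(F)(F)F)c1` were tested in a functional assay on HeLa cells (Homo sapiens) for cytotoxicity, read by MTT assay, with a stated time of 72 h; on this read-out higher numbers stand for weaker inhibition and lower numbers for stronger inhibition. Compound 1 gives 3100 nM, the lowest of the two numbers; compound 2 gives 7900 nM. Among the measured compounds shown here, the one measured step, a 2.5-fold higher number from compound 1 to compound 2 (0.41 log units; beyond the scatter), came from trifluoromethyl in place of methyl on an oxygen on an aromatic ring. Compound 3 `COc1cccc(/C=C/C(=O)Nc2cc(C(=O)c3cc(OC)c(OC)c(OC)c3)cc(OC)c2OC)c1` differs from compound 1 by methoxy in place of hydrogen on an aromatic carbon, a change at a different place, so that step offers no direct guide. For the measured compounds named here, with no bearing step, the expected change is none beyond the scatter, a 1.3-fold higher number from compound 1 to compound 3 (0.11 log units; within the scatter). Compound 3 is therefore estimated at 4000 nM, between 1500 nM and 11000 nM.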

Compound 3, half-maximal inhibitory concentration: 6900 nM
The estimate for compound 3 lay 1.7-fold (0.24 log units) below the measured number, within the range that was stated.
By their numbers in this assay, from the lowest: compound 1; then compounds 3 and 2 (each within the scatter of the next).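

Methoxy in place of hydrogen on this aromatic carbon, ortho to a methoxy group, gives a 2.2-fold higher number from compound 1 to compound 3 (0.35 log units; beyond the scatter), a modest loss of inhibition. Among the compounds shown here, the earlier step changed a different place, so this is the first sign that this carbon also affects the number, and that adding a group here does not leave it unchanged. No measurement available here explains the rise. As far as these compounds go, whether a hydroxy group, an amine or a fluorine atom on this same carbon would also raise the number remains open.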